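Swapping a difluorostyryl for an ethoxyphenyl on the benzyl arm

The source may report more compounds than this note shows. Statements on the series, on what has been measured and on what is new or still open speak of the compounds shown alone.

Compound 1 `COC(=O)/C=C/c1cccc(N(Cc2ccc(/C=C/c3c(F)cccc3F)cc2)C(=O)C(C)C)c1`: 108 nM
Compound 2 `COC(=O)/C=C/c1cccc(N(Cc2ccc(/C=C/c3scnc3C)cc2)C(=O)C2CCCCC2)c1`: 227 nM
Compound 3 `COC(=O)/C=C/c1cccc(N(Cc2ccc(-c3cccc(OC)c3)cc2)C(=O)NC(C)C)c1`: 1370 nM

Of the compounds shown here, three share a core and have been tested in an assay on isolated protein with Bile acid receptor (Homo sapiens) as the target; a higher number here means that more compound is needed for the effect, a lower number that less compound is needed. Compound 1 gives the lowest of the three numbers; compound 2 sits a little above it, beyond the scatter, and compound 3 gives by far the highest number, also beyond the scatter. Going by the values given here, no pair among the three differs in only one place, so the values are read on their own.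

Compound 4 `CCOc1cccc(-c2ccc(CN(C(=O)C(C)C)c3cccc(/C=C/C(=O)OC)c3)cc2)c1` has not been measured. It differs from compound 1 in one place: 3-ethoxyphenyl in place of 2-(2,6-difluorophenyl)ethenyl on an aromatic carbon. Nothing measured isolates this change. Compound 4 shares a directly attached aromatic ring at this position with compound 3, and compound 3 gives 1370 nM, though it also carries a different acyl group, so that number carries two changes at once. A moderate step toward a higher number is therefore expected, with a 3.7-fold higher number from compound 1 to compound 4 (0.57 log units; beyond the scatter) likely beyond the scatter. Compound 4 is estimated at 400 nM, with a range from 120 nM to 1400 nM.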

Compound 4, half-maximal effective concentration: 173 nM
For compound 4 the middle estimate is 2.3-fold (0.36 log units) above the measured one, within the range that was stated.
By their numbers in this assay, from the lowest: compounds 1, 4 and 2 (each within the scatter of the next, the first and the last beyond it); then compound 3.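

With the rest of the core held the same, 3-ethoxyphenyl in place of 2-(2,6-difluorophenyl)ethenyl on this aromatic carbon, para to a large group, gives a 1.6-fold higher number from compound 1 to compound 4 (0.20 log units; within the scatter) in this assay. Going by these compounds alone, this is the first step at this position that can be read on its own, and it shows that a directly attached aromatic ring and an ethenyl-linked one cannot be told apart here, even with the double bond and both fluorines gone and an oxygen brought in. Nothing at hand explains why these two groups read alike.

The compounds shown leave open whether an unsubstituted phenyl, or a 3-methoxyphenyl on the same acyl group, would read the same way. They also leave open how an amine or a carboxylic acid on this ring would fare.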